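Moving a Trifluoromethyl Group Around a Thioether Ring

The source may hold more compounds than are shown below. What is called first, only, known or untested is meant among the compounds shown, and "the series" means these compounds.

Of the compounds shown here, three sharing one core have been tested for how strongly they slow the growth of prostate cancer cells. In a functional assay on DU-145 cells (Homo sapiens) for antiproliferative activity, read by propidium iodide staining, with a stated time of 96 h (on this read-out higher numbers stand for weaker inhibition and lower numbers for stronger inhibition), compound 1 `CC(O)(CSc1cccc(S(F)(F)(F)(F)F)c1)C(=O)Nc1ccc(S(F)(F)(F)(F)F)cc1` gives 17300 nM. Compound 2 `CC(O)(CSc1ccc(F)cc1)C(=O)Nc1ccc(S(F)(F)(F)(F)F)cc1` gives 25400 nM in this assay. Compound 3 `CC(O)(CSc1ccc(C(F)(F)F)cc1)C(=O)Nc1ccc(S(F)(F)(F)(F)F)cc1` gives 28800 nM in this assay, the highest of the three numbers, but its gap to compound 2 and to compound 1 lies within the usual scatter, so the three cannot be ranked.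

The next compound, compound 4 `CC(O)(CSc1cccc(C(F)(F)F)c1)C(=O)Nc1ccc(S(F)(F)(F)(F)F)cc1`, has the same atoms as compound 3 joined differently: 3-(trifluoromethyl)phenyl in place of 4-(trifluoromethyl)phenyl on a sulfur. Among the compounds with values here, the one measured step, a 1.1-fold higher number from compound 2 to compound 3 (0.05 log units; within the scatter), concerns a different kind of change, swapping one group for another rather than moving a group within the ring, and it stays within the scatter. Compound 1 differs from compound 3 in two places at once, so it offers no clean comparison; the values of compound 1 and compound 3 lie within the scatter of each other. Since every comparison available stays within the scatter, compound 4 is expected to show a 1.2-fold lower number from compound 3 to compound 4 (0.08 log units; within the scatter), that is, no step beyond the scatter. The estimate for compound 4 is 24000 nM, with a range from 12000 nM to 48000 nM.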

Compound 4, half-maximal inhibitory concentration: 26200 nM
For compound 4 the middle estimate is 1.1-fold (0.04 log units) below the measured one; low and high end bracket the measured number.
By their numbers in this assay, from the lowest: compounds 1, 2, 4 and 3 (each within the scatter of the next).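

Moving the trifluoromethyl group, so that 3-(trifluoromethyl)phenyl replaces 4-(trifluoromethyl)phenyl on the sulfur, gives a 1.1-fold lower number from compound 3 to compound 4 (0.04 log units; within the scatter) in this assay; this is the first look at a shift of one group within the ring rather than a swap of one group for another, and on this read-out the shift makes no measurable difference. The swaps around compound 4 also stay within the scatter: replacing 4-fluorophenyl with 3-(trifluoromethyl)phenyl on the sulfur gives a 1.0-fold higher number from compound 2 to compound 4 (0.01 log units; within the scatter), and replacing the six-atom group of sulfur and five fluorines with trifluoromethyl on an aromatic carbon gives a 1.5-fold higher number from compound 1 to compound 4 (0.18 log units; within the scatter). No measurement beyond these cell numbers is available to explain why the values stay so close.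

Going by these compounds, whether a different kind of group on this ring, such as an amine or a carboxylic acid, would shift the number beyond the scatter remains open, as does the effect of a longer chain on the sulfur in place of the ring. With no step beyond the scatter among these four compounds, they do not yet show which changes at this place matter.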